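From dimethylfuran to methylfuran on the shared carbonyl

This account rests on a few compounds, and the source may have more. Where it says the series, first, only, none or still open, it means among the compounds named here.

In an ADME assay on L6 cells (Rattus norvegicus) for cytotoxicity, read by resazurin assay, with a stated time of 72 h (a lower number here means a stronger inhibitor, a higher number a weaker inhibitor), compound 1 `Cc1csc(C(=O)NCCCn2cnc([N+](=O)[O-])n2)c1` gives 173000 nM. Compound 2 `O=C(NCCCn1cnc([N+](=O)[O-])n1)c1ccsc1` reads > 356000 nM, which is a limit. Compound 3 `Cc1cc(C(=O)NCCCn2cnc([N+](=O)[O-])n2)c(C)o1` reads > 341000 nM, again only a limit. Compound 4 `Cc1ccoc1C(=O)NCCCn1cnc([N+](=O)[O-])n1` carries 3-methylfuran-2-yl in place of 2,5-dimethylfuran-3-yl on a carbonyl carbon. Among the measured compounds shown here, two measured steps bear on this change: an at least 2.0-fold higher number from compound 1 to compound 2 (0.31 log units; beyond the scatter) and an at least 1.9-fold higher number from compound 1 to compound 3 (0.29 log units; that floor lies within the scatter). Both show that exchanging the group on the carbonyl carbon can move the number, although the floor of the second lies within the scatter. For the measured compounds named here, compound 1 at 173000 nM is the only firm reading. In this assay, the estimated change is an at least 1.4-fold lower number from compound 3 to compound 4 (0.15 log units; that floor lies within the scatter), a modest expected move toward a lower number. For compound 4 the expected value is 240000 nM, with an estimated range of 110000 nM to 400000 nM.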

Compound 4, half-maximal inhibitory concentration: > 358000 nM
Compound 4 ended at the assay's limit (the forecaster's own chance of this, stated with the estimate: 45%); middle value at least 1.4-fold (0.17 log units) away from the limit.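

In this assay compound 4 reads > 358000 nM, which is a limit. Against the only firm reading the result is an at least 2.0-fold higher number from compound 1 to compound 4 (0.31 log units; beyond the scatter), so a methylfuran on the carbonyl carbon now clears the scatter, as thiophen-3-yl did with an at least 2.0-fold higher number from compound 1 to compound 2 (0.31 log units; beyond the scatter), whereas the dimethylfuran gave only an at least 1.9-fold higher number from compound 1 to compound 3 (0.29 log units; that floor lies within the scatter). The steps to compound 4 from compound 2 and from compound 3 join two limits and cannot be read.

On these data alone, how these three groups rank among themselves stays open. So does what a carboxylic acid on the furan would read.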